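This account rests on a few compounds, and the source may have more. Where it says the series, first, only, none or still open, it means among the compounds named here.

The series shares a core carrying an amino group, two aryl substituents and a carbonyl-linked amine, and it is followed in a functional assay on PC-3 cells (Homo sapiens) for cytotoxicity, read by sulforhodamine B assay, with a stated time of 72 h; on this read-out lower numbers stand for stronger inhibition and higher numbers for weaker inhibition. Compound 1 `Nc1sc(-c2ccccc2)c(-c2ccc(Cl)cc2)c1C(=O)N1CCCC1` gives 22200 nM in this assay, and compound 2 `Nc1sc(-c2ccc(F)cc2)c(-c2ccc(Cl)cc2)c1C(=O)N1CCCC1` gives 20400 nM. For the measured compounds named here, the one step that connects them, a 1.1-fold lower number from compound 1 to compound 2 (0.04 log units; within the scatter), changes a substituent on an aryl ring and leaves the amine on the carbonyl carbon untouched. Compound 3 `Nc1sc(-c2ccc([N+](=O)[O-])cc2)c(-c2ccc(Cl)cc2)c1C(=O)NC1CC1` stands apart: in this assay compound 3 gives "not determined" (no result reported), so no number places it against compounds 1 and 2.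

Compound 4 `Nc1sc(-c2ccc([N+](=O)[O-])cc2)c(-c2ccc(Cl)cc2)c1C(=O)N1CCCC1` differs from compound 3 in one place, (pyrrolidin-1-yl in place of cyclopropylamino on a carbonyl carbon). Going by the values given here, none of the measured steps touches the amine on the carbonyl carbon, so no step bears on this change; the only measured step, from compound 1 to compound 2, concerns an aryl substituent and lies within the scatter. What can be drawn on is that compounds 1 and 2 both carry the same pyrrolidin-1-yl amide that enters in compound 4 and both sit in the same region of this assay.

On that basis compound 4 is expected to give roughly 20000 nM in this assay, with a plausible span from 5000 nM to 80000 nM.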

Compound 4, half-maximal inhibitory concentration: 42600 nM
For compound 4 the middle estimate is 2.1-fold (0.33 log units) below the measured one, within the range that was stated.
By their numbers in this assay, from the lowest: compounds 2, 1 and 4 (each within the scatter of the next, the first and the last beyond it).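

For the compounds shown here, compound 4 gives the first reading of a nitro group on an aromatic carbon in this assay, with the pyrrolidin-1-yl amide held constant. Set against the fluoro analogue, nitro gives a modest step beyond the scatter (a 2.1-fold higher number from compound 2 to compound 4 (0.32 log units; beyond the scatter)), whereas set against the unsubstituted analogue it gives a step within the scatter (a 1.9-fold higher number from compound 1 to compound 4 (0.28 log units; within the scatter)), so only the first of these two comparisons separates the compounds. The change at the carbonyl carbon itself, from cyclopropylamino to pyrrolidin-1-yl, cannot be read, nor can any other step from compound 3, as compound 3 has no result, and no measurement shown offers an explanation for the steps that can be read.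

As far as these compounds go, it therefore remains open how the cyclopropylamino and pyrrolidin-1-yl groups compare on the carbonyl carbon when the rest of the structure is the same. Also open, from the compounds shown here alone, is how a piperidin-1-yl or morpholin-4-yl group on that carbon, or a methoxy group or a carboxylic acid in place of the nitro group, would read in this assay.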